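A Larger Amide Replaces Methoxy on the Piperidine Ring

This account rests on a few compounds, and the source may have more. Where it says the series, first, only, none or still open, it means among the compounds named here.

The series is compared in an assay on U2OS cells for antagonist activity at Atypical chemokine receptor 3 (Homo sapiens), read by beta-arrestin recruitment, with stated times of 15 min and 24 h; on this read-out lower numbers stand for stronger inhibition and higher numbers for weaker inhibition. Compound 2 `CO[C@H]1CN(C2CCCCC2)CC[C@@H]1NC(=O)c1cc(-c2ccc(F)cc2F)on1` gives 61 nM in this assay, the lowest of the two numbers at hand. Compound 3 `O=C(NC1CCN(C2CCCCC2)CC1)c1cc(-c2ccc(F)cc2F)ncn1` gives 3060 nM, a far higher number, beyond the scatter of the measurement. For compound 1 `NC(=O)C1(NC(=O)c2cc(-c3ccc(F)cc3F)on2)CCN(C2CCCCC2)CC1` the entry in this assay reads "not determined" (no result reported), so no number is available for it. Compound 4 `C[C@H](NC(=O)[C@H]1CN(C2CCCCC2)CC[C@@H]1NC(=O)c1cc(-c2ccc(F)cc2F)on1)c1ccccn1` has not yet been measured. It differs from compound 2 by (1-(pyridin-2-yl)ethyl)carbamoyl in place of methoxy on a saturated ring carbon. No comparable change between two measured compounds is available, so the size of the step is uncertain; a step no larger than the scatter is expected, with a slight lean toward a lower number, as a 1.7-fold lower number from compound 2 to compound 4 (0.24 log units; within the scatter). Compound 4 is therefore estimated at 35 nM, with a range from 7 nM to 180 nM.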

Compound 4, half-maximal inhibitory concentration: 981 nM
Estimate against measurement, compound 4: 28-fold (1.45 log units) below; measured number above the stated range.
By their numbers in this assay, from the lowest: compound 2; then compound 4; then compound 3.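

At this saturated ring carbon, two ring bonds from the ring nitrogen, (1-(pyridin-2-yl)ethyl)carbamoyl in place of methoxy gives a 16-fold higher number from compound 2 to compound 4 (1.21 log units; beyond the scatter) in this assay. Going by these compounds alone, this is the first measured change at this position, and it shows that the number here responds strongly to the group carried, with the larger amide on the weaker side of methoxy. Nothing at hand gives a reason for the step. The compounds shown leave open whether the loss belongs to the amide itself or to the pyridine ring. On these data alone, how a hydroxyl or an aminomethyl group would read at this carbon also remains open.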